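A few compounds are considered here, and "the series" means these few. Any claim that something is new, unique, unknown or untested is made for them only; others in the source may bear on it.

Compound 1 `CCc1cc(C(C)=O)c(O)cc1OCCCCCC(C)(C)C(=O)O` and compound 2 `CCc1cc(C(C)=O)c(O)cc1OCCCCCCC(C)(C)c1nnn[nH]1` share one core and differ only at the end of the chain that hangs from the ring oxygen. In an assay on isolated protein for binding affinity to leukotriene B4 receptor 1 (Homo sapiens), tested at 1 uM (a lower number here means less inhibition, a higher number more inhibition at the concentration tested (going by the name of the read-out)), compound 1 gives 73%, and in this assay compound 2 gives 67%; the step of a number 6 percentage points lower from compound 1 to compound 2 (within the scatter) lies within the usual scatter, so the two numbers stand level with each other. Compound 3 `CCc1cc(C(C)=O)c(O)cc1OCCCCCC(C)(C)c1nnn(C)n1` is the next step from compound 2. The change 1-methyl-1-(2-methyl-2H-tetrazol-5-yl)ethyl in place of 2-(1H-tetrazol-5-yl)-2-methylpropyl on a saturated chain carbon, five bonds along the chain from an oxygen on an aromatic ring keeps every atom but joins them differently: the ring carries a methyl group, and the chain is one carbon shorter. Among the compounds with values here, no measured step touches this ring or the chain length, so the one step seen gives no direct guide, only a hint that an alteration at the end of the chain left the number in this assay level. For compound 3 a value of about 55% is therefore expected, with a wide range from 30% to 78%. The expected step of a number 12 percentage points lower from compound 2 to compound 3 (beyond the scatter) is a modest fall that may not exceed the scatter.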

Compound 3, a percentage reported as inhibition, at one concentration (the size of the read-out at that concentration, not a potency): 66%
Estimate against measurement, compound 3: 11 percentage points below, within the range that was stated.
By their numbers in this assay, from the lowest: compounds 3, 2 and 1 (each within the scatter of the next).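

In this assay, the swap on this chain end gives a number 1 percentage points lower from compound 2 to compound 3 (within the scatter), even though the entering group carries 0 hydrogen-bond donors where the leaving group carries 1, and the chain is one carbon shorter. Setting 2-methyl-2H-tetrazol-5-yl in place of carboxy gives a number 7 percentage points lower from compound 1 to compound 3 (within the scatter), so the carboxy end and both tetrazole ends stand level at this place, at the one concentration tested. No measurement at hand explains why these ends stand level.

On these data alone, with the ring and the chain length changing together in the swap, the share of each remains unknown. Also open, as far as these compounds go, is whether the level would hold with a quite different end, such as an amine or a primary amide, or on a much longer chain.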